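The source may report more compounds than this note shows. Statements on the series, on what has been measured and on what is new or still open speak of the compounds shown alone.

Compound 1, `NC(=O)/C=C1\CCc2c1ccc(F)c2F`, gives 45 mg/kg in a functional assay on the whole organism with Mus musculus as the target; a lower number here means that less compound is needed, a higher number that more compound is needed for the effect.
Compound 2, `Cc1cccc2c1CC/C2=C\C(N)=O`, gives in this assay only a limit, > 100 mg/kg.
Compound 3, `NC(=O)/C=C1\CCc2c(F)ccc(F)c21`, gives 56 mg/kg.

Compound 3 and compound 1 both carry two fluoro groups on the shared core, and their two numbers sit within the usual scatter of each other, so neither can be set above the other. For compound 2 the assay reports only (the limit of > 100 mg/kg in this assay, at which 1 of the 3 values shown sits), so its number is not known. Compound 4, `NC(=O)/C=C1\CCc2c(F)cccc21`, has not yet been measured. It differs from compound 3 in one place: hydrogen in place of fluoro on an aromatic carbon. Within the data shown here, no measured pair of this kind exists, so the expected step in this assay is a guess: a moderate move toward a higher number, about a 1.4-fold higher number from compound 3 to compound 4 (0.15 log units; within the scatter). Compound 4 is therefore expected to need 80 mg/kg, most likely between 35 mg/kg and 160 mg/kg.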

Compound 4, dose for half-maximal effect: > 100 mg/kg
Compound 4 was reported as a limit; the forecaster's own chance of this, stated with the estimate: 30%; at least 1.2-fold (0.09 log units) between middle value and limit.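

Replacing one fluoro group with hydrogen at this aromatic carbon, para to a fluoro group, gives an at least 1.7-fold higher number from compound 3 to compound 4 (0.25 log units; that floor lies within the scatter). Among these compounds, the same kind of change gives an at least 2.2-fold higher number from compound 1 to compound 4 (0.34 log units; beyond the scatter), the first step to clear the scatter, so in this assay a second fluoro group on the shared core appears to matter. Both steps are only floors because compound 4 reached a limit: the limit of > 100 mg/kg in this assay, at which 2 of the 4 values shown sit.

The step between compound 2 and compound 4 cannot be read. From the compounds shown here alone, it remains open how a chloro or methoxy group at this aromatic carbon would compare with fluoro.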